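Mirror Image of Compound 1: Expected Inhibition

The source may report more compounds than this note shows. Statements on the series, on what has been measured and on what is new or still open speak of the compounds shown alone.

Measured so far:
compound 1 `O=C(O)[C@H]1NC[C@H](O)[C@@H](O)[C@@H]1O`: 0.2%
compound 2 `O=C(O)[C@H]1NC[C@@H](O)[C@@H](O)[C@@H]1O`: 3.8%
compound 3 `O=C(O)[C@@H]1NC[C@H](O)[C@@H](O)[C@@H]1O`: 3.4%

In an assay for inhibition of alpha-N-acetylgalactosaminidase (Gallus gallus), tested at 1000 uM (on this read-out higher numbers stand for more inhibition at the one concentration tested (going by the name of the read-out) and lower numbers for less inhibition), compound 1 gives 0.2%, the smallest of the three numbers, yet all three sit within the usual scatter of one another. Compound 4 `O=C(O)[C@@H]1NC[C@@H](O)[C@H](O)[C@H]1O` is not yet measured; it differs from compound 1 in that (the two compounds have the same atoms and bonds and differ only in configuration as drawn: 4 of 4 stereo elements differ (all stereocentres are inverted: mirror images); a stereocentre at a saturated ring carbon is drawn S in compound 1 and R in compound 4; a stereocentre at a saturated ring carbon is drawn S in compound 1 and R in compound 4; a stereocentre at a saturated ring carbon is drawn R in compound 1 and S in compound 4; a stereocentre at a saturated ring carbon is drawn R in compound 1 and S in compound 4). The measured steps that bear on this are all changes of configuration alone: a number 3.6 percentage points higher from compound 1 to compound 2 (within the scatter), a number 3.2 percentage points higher from compound 1 to compound 3 (within the scatter) and a number 0.4 percentage points lower from compound 2 to compound 3 (within the scatter). None of them moved the read-out beyond the scatter. A step of a number 1.8 percentage points higher from compound 1 to compound 4 (within the scatter) is therefore expected, that is, no change beyond the scatter in either direction. Compound 4 is estimated at 2%, within a range from 0% to 10%.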

Compound 4, a percentage reported as inhibition, at one concentration (the size of the read-out at that concentration, not a potency): 1.3%
The estimate for compound 4 lay 0.7 percentage points above the measured number; the measured number falls inside the stated range.
By their numbers in this assay, from the lowest: compounds 1, 4, 3 and 2 (each within the scatter of the next).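

Even the mirror image, the largest change of configuration possible here, leaves the read-out in this assay unmoved, with a number 1.1 percentage points higher from compound 1 to compound 4 (within the scatter). Changing three stereocentres at once does no more, giving a number 2.5 percentage points lower from compound 2 to compound 4 (within the scatter) and a number 2.1 percentage points lower from compound 3 to compound 4 (within the scatter). So inverting every stereocentre adds nothing beyond the smaller changes seen earlier.

With every number this close to zero, these compounds cannot show whether configuration would matter in a compound that clearly inhibits this enzyme. As far as these compounds go, whether a methyl ester or an amide in place of the carboxylic acid would give real inhibition remains open.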